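Cytotoxicity limits and the step to compound 4

The source may report more compounds than this note shows. Statements on the series, on what has been measured and on what is new or still open speak of the compounds shown alone.

In an ADME assay on Karpas-1106P cells (Homo sapiens) for cytotoxicity (on this read-out higher numbers stand for an effect only at larger amounts of compound and lower numbers for an effect already at smaller amounts), compound 1 (`COc1cccc(C(=O)NCCNC(=O)[C@H](CC(=O)NC(C)(C)C)NS(=O)(=O)c2ccc(C)cc2)c1`) gives only a limit (> 11100 nM). Compound 2 (`Cc1ccc(S(=O)(=O)N[C@@H](CC(=O)NC(C)(C)C)C(=O)NCCNC(=O)c2cccc(F)c2)cc1`) also gives only a limit (> 11100 nM). Compound 3 (`Cc1ccc(S(=O)(=O)N[C@@H](CC(=O)NC(C)(C)C)C(=O)NCCNC(=O)c2cccc(C#N)c2)cc1`) likewise gives only a limit (> 11100 nM). Compound 3 therefore stands at a shared position (the limit of > 11100 nM in this assay, at which 3 of the 3 values shown sit), with no order readable among the three.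

Compound 4 (`Cc1ccc(S(=O)(=O)N[C@@H](CC(=O)NC(C)(C)C)C(=O)NCCNC(=O)c2cc(Cl)ccc2Cl)cc1`) carries 2,5-dichlorophenyl in place of 3-cyanophenyl on a carbonyl carbon. The measured steps (a step that the two limits leave unreadable from compound 1 to compound 2), (a step that the two limits leave unreadable from compound 1 to compound 3) and (a step that the two limits leave unreadable from compound 2 to compound 3) have no readable size. No shift beyond the scatter is therefore expected in this assay, and no direction is assigned. The expected step is small (a step that the limit leaves unreadable from compound 3 to compound 4). Compound 4 is estimated at (12000 nM), with an expected range from 5000 nM to 25000 nM and a limit reading likely.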

Compound 4, half-maximal effective concentration: > 11100 nM
Compound 4 was reported as a limit; the forecaster's own chance of this, stated with the estimate: 75%; the middle value does not contradict the limit.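

No step from compound 1, compound 2 or compound 3 to compound 4 can be read in this assay, because all four compounds give the same limit: the limit of > 11100 nM in this assay, at which 4 of the 4 values shown sit.

The compounds shown leave open whether any group on the carbonyl carbon shifts the read-out, and at what concentration any of the four has an effect.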